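The source may report more compounds than this note shows. Statements on the series, on what has been measured and on what is new or still open speak of the compounds shown alone.

In an assay on HEK293-A cells with putative P2Y purinoceptor 10 (Mus musculus) as the target, with a stated time of 1.5 h (a higher number here means a larger maximal response, a lower number a smaller maximal response), compound 1, with structure `CCCCCCCCCCCOc1ccccc1CCC(=O)OCc1ccccc1OP(=O)(O)OC[C@H](N)C(=O)O`, gives 0.02, a very small maximal response. Compound 2, with structure `CCCCCCCC/C=C\CCCCCCCC(=O)O[C@H]1CCCO[C@@H]1COP(=O)(O)OC[C@H](N)C(=O)O`, shares the phosphoserine head with compound 1 but carries a saturated ring core bearing an unsaturated long-chain ester. In this assay compound 2 is recorded as "not active" (no number reported), so no single number stands for it and it cannot be placed against compound 1 on a scale. Compound 3, with structure `CCCCCCCC/C=C\CCCCCCCC(=O)O[C@@H]1CCCO[C@@H]1COP(=O)(O)OC[C@H](N)C(=O)O`, is the next step and differs from compound 2 as follows: the two compounds have the same atoms and bonds; at least one stereo element is drawn with a configuration in one of them and without one in the other: 1 of 5 stereo elements differ; a stereocentre at a saturated ring carbon is drawn S in compound 2 and R in compound 3. Nothing here shows how far such a flip at one ring stereocentre moves the response, and no measured pair of this kind exists among these compounds, so the expected step is small, perhaps none beyond the scatter, in either direction. Compound 3 is therefore expected to show a maximal response of about 0.05, estimated to lie between 0 and 0.3.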

Compound 3, intrinsic activity: the largest response reached, as a fraction of the reference agonist's: "not active" (no number reported)
Nothing numeric was reported for compound 3; the estimate stays without a comparison.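

In this assay compound 2 and compound 3 are both recorded as not active, so no step can be read between them, and all that separates them is this: the fact that one of compounds 2 and 3 is drawn with a defined configuration and the other without, at the place where they differ. The compounds shown leave open whether this ring stereocentre can change the maximal response at all.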